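Methylsulfanyl in place of the selenium arm: series notes

A few compounds are considered here, and "the series" means these few. Any claim that something is new, unique, unknown or untested is made for them only; others in the source may bear on it.

The series rests on two cores. Compound 1 `O=C(/N=C(/NC(=O)c1cc(-c2ccccc2)nc2ccccc12)[Se]Cc1ccccc1)c1cc(-c2ccccc2)nc2ccccc12` carries one, compound 2 `O=C(/N=C(/NC(=O)c1cccs1)[Se]Cc1ccccc1)c1cccs1` the other; the difference between the two cores is not broken down here. In a functional assay on HepG2 cells (Homo sapiens) for cytotoxicity, read by MTT assay, with a stated time of 72 h (on this read-out higher numbers stand for weaker inhibition of growth and lower numbers for stronger inhibition of growth), compound 1 gives 25800 nM. In this assay compound 2 gives 34700 nM, which sits within the scatter of compound 1. Compound 3 `CS/C(=N\C(=O)c1cccs1)NC(=O)c1cccs1` keeps the core of compound 2 with a group of 2 heavy atoms (1 carbon, 1 sulfur; no ring) in place of a group of 8 heavy atoms (7 carbon, 1 selenium; one six-membered aromatic ring of carbon only), on a carbon with a double bond to nitrogen. In this assay compound 3 reaches only a limit of the assay, > 100000 nM. The step of an at least 2.8-fold higher number from compound 2 to compound 3 (0.45 log units; beyond the scatter) is therefore bounded on one side only, because it rests on (the limit of > 100000 nM in this assay, at which 1 of the 3 values shown sits).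

Compound 4 `CS/C(=N\C(=O)c1cc(-c2ccccc2)nc2ccccc12)NC(=O)c1cc(-c2ccccc2)nc2ccccc12` makes the same change on the core of compound 1: a group of 2 heavy atoms (1 carbon, 1 sulfur; no ring) in place of a group of 8 heavy atoms (7 carbon, 1 selenium; one six-membered aromatic ring of carbon only), on a carbon with a double bond to nitrogen. The change sits at the same place in both pairs, so it is the same change, not merely the same kind. The step expected from compound 1 to compound 4 in this assay is a 3.5-fold higher number from compound 1 to compound 4 (0.54 log units; beyond the scatter), set beside an at least 2.8-fold higher number from compound 2 to compound 3 (0.45 log units; beyond the scatter); it rests on that single pair and on the starting value of compound 1, 25800 nM. Compound 4 is therefore estimated at 90000 nM, with a range of 40000 nM to 250000 nM, and a fair chance that only a limit is reported.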

Compound 4, concentration for 50% growth inhibition: 6240 nM
Estimate against measurement, compound 4: 14-fold (1.16 log units) above; the whole stated range lies above it.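

In this assay the exchange of the selenium arm for methylsulfanyl gives a 4.1-fold lower number from compound 1 to compound 4 (0.62 log units; beyond the scatter), and the same change therefore runs in opposite directions on the two cores, so it does not carry from one core to the other in this series: the same change on two cores in this assay, an at least 2.8-fold higher number (0.45 log units; beyond the scatter) from compound 2 to compound 3 and a 4.1-fold lower number (0.62 log units; beyond the scatter) from compound 1 to compound 4, at least 11-fold (1.07 log units) apart, beyond the scatter of two such steps

Compound 3 gives > 100000 nM, which is a limit of the assay and not a number: the limit of > 100000 nM in this assay, at which 1 of the 4 values shown sits.

The two pairs show that the result of this change cannot be read across between these cores, but they do not show which part of either core sets the direction, and two cores give no rule for a third.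

The compounds shown change the selenium and the size of the arm together, so it remains open which of the two goes with the reversal; a benzylsulfanyl arm or a methylselanyl arm on each core would separate them. Also open, from the compounds shown here alone, is how a longer alkylsulfanyl chain or an amine at the same carbon would behave on either core.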